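Dichloro analogue in a cytotoxicity test

The source may hold more compounds than are shown below. What is called first, only, known or untested is meant among the compounds shown, and "the series" means these compounds.

Compound 1 `Clc1ccccc1-c1cnc(Nc2ccc3[nH]ncc3c2)o1` and compound 2 `Clc1ccc(-c2cnc(Nc3ccc4[nH]ncc4c3)o2)cc1` were examined in an ADME assay on MT4 cells (Homo sapiens) for cytotoxicity, read by WST assay; on this read-out higher numbers stand for lower toxicity in this test and lower numbers for higher toxicity in this test. In this assay compound 1 gives > 100 uM, which is a limit of the test and not a number. In this assay compound 2 also reaches only a limit, > 90 uM. The step that the two limits leave unreadable from compound 1 to compound 2 therefore cannot be read, since both values the limit of > 100 uM in this assay, at which 1 of the 2 values shown sits, and the limit of > 90 uM in this assay, at which 1 of the 2 values shown sits, are limits. Compound 3 `Clc1ccc(-c2cnc(Nc3ccc4[nH]ncc4c3)o2)cc1Cl` has not yet been measured; it differs from compound 2 by chloro in place of hydrogen on an aromatic carbon. Going by the values given here, no measured step bears directly on this change, and the one measured step is itself unreadable, so no direction can be drawn from it. Compound 3 is therefore expected to stay close to where compound 2 stands, with an estimated step of an at least 1.2-fold lower number from compound 2 to compound 3 (0.10 log units; that floor lies within the scatter). The estimate for compound 3 in this assay is 70 uM, expected to fall between 30 uM and 120 uM.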

Compound 3, half-maximal toxic concentration: > 100 uM
Compound 3: a limit, no number; the forecaster's own chance of this, stated with the estimate: 55%; at least 1.4-fold (0.15 log units) between middle value and limit.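

The step from compound 2 to compound 3 cannot be read in this assay: both values are limits of the test and not numbers. The compounds shown leave open whether chloro in place of hydrogen on this aromatic carbon changes the half-maximal toxic concentration at all.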